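The compounds below may be only part of what the source reports. "The series", "measured", "known", "first", "only" and "open" are said of these compounds alone.

Measured so far:
compound 1 `COc1ccc2cc(C(=O)CCN(C)C)c(=O)oc2c1`, > 100000 nM, a limit of the assay
compound 2 `COc1ccc2cc(C(=O)CCN3CCCCC3)c(=O)oc2c1`, > 100000 nM, a limit of the assay
compound 3 `Cc1cc(O)cc2oc(=O)c(C(=O)CCN(C)C)cc12`, 19700 nM

In a functional assay on SH-SY5Y cells (Homo sapiens) for cytotoxicity, read by MTT assay, with stated times of 1 h and 24 h (a lower number here means that less compound is needed, a higher number that more compound is needed for the effect), compound 1 reaches only a limit, > 100000 nM. Compound 2 likewise reaches only a limit, > 100000 nM. Going by the values given here, compound 3 is the one compound with a number, 19700 nM. Compound 1 and compound 3 hold the same atoms joined differently; the difference between the two cores is not broken down here. The change piperidin-1-yl in place of dimethylamino on a saturated chain carbon, two bonds along the chain from a carbonyl carbon gave a step that the two limits leave unreadable from compound 1 to compound 2, unreadable because both values sit at the limit of > 100000 nM in this assay, at which 2 of the 3 values shown sit. Compound 4 `Cc1cc(O)cc2oc(=O)c(C(=O)CCN3CCCCC3)cc12`, not yet measured, carries the same change on the core of compound 3: piperidin-1-yl in place of dimethylamino on a saturated chain carbon, two bonds along the chain from a carbonyl carbon. With no readable size from the earlier step, the step from compound 3 to compound 4 is estimated to stay within scatter, a 1.0-fold higher number from compound 3 to compound 4 (0.01 log units; within the scatter). Compound 4 is therefore expected near 20000 nM in this assay, between 7000 nM and 60000 nM.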

Compound 4, half-maximal effective concentration: 83700 nM
The estimate for compound 4 lay 4.2-fold (0.62 log units) below the measured number, and the stated range ends below it.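

In this assay, piperidin-1-yl in place of dimethylamino on the core of compound 3 gives a readable step (a 4.2-fold higher number from compound 3 to compound 4 (0.63 log units; beyond the scatter)). The matching step on the core of compound 1 cannot be read, because both of its values are limits of the assay: the limit of > 100000 nM in this assay, at which 2 of the 4 values shown sit. The change therefore has a size on one core only, and nothing shows whether that size carries over from one core to the other.

As far as these compounds go, it remains open whether pyrrolidin-1-yl or morpholin-4-yl, on a saturated chain carbon two bonds along the chain from a carbonyl carbon, would read closer to dimethylamino or to piperidin-1-yl on the core of compound 3. From the compounds shown here alone, a longer chain between the carbonyl and the amine is also open.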